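The source may hold more compounds than are shown below. What is called first, only, known or untested is meant among the compounds shown, and "the series" means these compounds.

Compound 1 `CCCCC(Nc1c(C#N)c(-c2ccc(-c3ccccc3OCC)cc2)nc2cnccc12)C(N)=O` is the most lipophilic of the three measured compounds in a physicochemical assay for lipophilicity, read by HPLC, at pH 7.5 (on this read-out lower numbers stand for lower lipophilicity and higher numbers for higher lipophilicity), where compound 1 gives 3.6. The nearest of the others is compound 3 `CC[C@@H](Nc1c(C#N)c(-c2ccc(-c3ccccc3N(C)C)cc2)nc2cnccc12)C(N)=O`, which in this assay gives 3.2, and the furthest is compound 2 `CC[C@@H](Nc1c(C#N)c(-c2ccc(-c3ccccc3C(F)(F)F)cc2)nc2cnccc12)C(N)=O`, which in this assay gives 3.1; both gaps lie beyond the scatter.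

Compound 4 `CCOc1ccccc1-c1ccc(-c2nc3cnccc3c(N[C@H](CC)C(=O)N(C)C)c2C#N)cc1` is not yet measured. It differs from compound 1 in one place: 1-(dimethylcarbamoyl)propyl in place of 1-carbamoylpentyl on a nitrogen on an aromatic ring. The only measured step among these compounds, a number 0.10 log units higher from compound 2 to compound 3 (within the scatter), concerns a group on an aromatic carbon and so does not touch the part of the molecule that is altered here. Among the compounds with values here, no measured step bears on the change from compound 1 to compound 4.

With nothing to draw on beyond the unchanged atom count, the reasonable expectation is a step of about a number 0.10 log units higher from compound 1 to compound 4 (within the scatter), that is, no change beyond the scatter. Compound 4 is therefore estimated at 3.7 in this assay, with a range from 3.3 to 4.1.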

Compound 4, distribution coefficient: 3.7
Compound 4: middle estimate and measured number agree at the digits printed; measured number inside the range.
By their numbers in this assay, from the lowest: compounds 2 and 3 (each within the scatter of the next); then compounds 1 and 4 (each within the scatter of the next).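

This position, untouched by the earlier step, now has a measured step: a number 0.10 log units higher from compound 1 to compound 4 (within the scatter) in this assay with 1-(dimethylcarbamoyl)propyl in place of 1-carbamoylpentyl. A group with 1 hydrogen-bond donor gave way to one with 0 hydrogen-bond donors, at 8 heavy atoms each and with a propyl in place of a pentyl chain, and the number stayed within the scatter. The two differences are joined in this one step, and nothing measured here explains the outcome.

As far as these compounds go, it remains open how 1-carbamoylpropyl or 1-(dimethylcarbamoyl)pentyl would read on this nitrogen with the rest of compound 1 held, which would separate the chain from the amide methyl groups. Also open, from the compounds shown here alone, is whether a carboxylic acid or an amine in place of the amide would move the number beyond the scatter.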